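The source may hold more compounds than are shown below. What is called first, only, known or untested is meant among the compounds shown, and "the series" means these compounds.

Compound 1, with the structure `CCCc1nc(-c2ccccc2)c(CNCCN2CCN(c3ccccc3F)CC2)o1`, was tested in an assay on HEK293 cells for inhibition of Voltage-dependent T-type calcium channel subunit alpha-1G (Homo sapiens), read by fluorescence, tested at 10 uM (a higher number here means more inhibition at the concentration tested (going by the name of the read-out), a lower number less inhibition), and gave 46.5%. Two relatives share much of its shape. Compound 2, `CCCc1nc(-c2ccccc2)c(CNCCCN2CCN(c3ccc(OC)cc3)CC2)o1`, gives 42.1% in this assay, and compound 3, `Cc1nc(-c2ccccc2)c(CNCCCN2CCN(c3ccc(Cl)cc3)CC2)o1`, gives 38.1%. Compound 1 sits at the top of these three numbers, but its distances to compound 2 and to compound 3 both fall within the usual scatter of such measurements, so the three cannot be told apart on this evidence.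

Compound 4, `CCCc1nc(-c2ccccc2)c(CNCCN2CCN(c3cccc(F)c3)CC2)o1`, has not yet been measured. It differs from compound 1 by 3-fluorophenyl in place of 2-fluorophenyl on an amine nitrogen in a ring: the same atoms are present, joined differently, with 3-fluorophenyl taking the place of 2-fluorophenyl on an amine nitrogen in a ring. Within the data shown here, no measured pair in this set shows what moving a fluorine around that ring does, so there is nothing to lean on beyond the closeness of the three known values. The expectation is therefore a step from compound 1 to compound 4 of about a number 1.5 percentage points lower from compound 1 to compound 4 (within the scatter), meaning none beyond the scatter. Compound 4 is expected to give roughly 45% in this assay, within a range from 30% to 60%.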

Compound 4, a percentage reported as inhibition, at one concentration (the size of the read-out at that concentration, not a potency): 62.3%
For compound 4 the middle estimate is 17.3 percentage points below the measured one, and the stated range ends below it.
By their numbers in this assay, from the lowest: compounds 3, 2 and 1 (each within the scatter of the next); then compound 4.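

In this assay, 3-fluorophenyl in place of 2-fluorophenyl on an amine nitrogen in a ring gives a number 15.8 percentage points higher from compound 1 to compound 4 (beyond the scatter). The earlier compounds shown here could not show this, since they differ from each other in more than one place and their numbers lie within the scatter; this pair shows that where the fluorine sits on the phenyl ring can matter on its own, with the same atoms present and the rest of the structure unchanged. Nothing available here explains why the read-out responds to this move.

The compounds shown leave open whether this step is specific to fluorine or would also appear with another group on the phenyl ring, such as trifluoromethyl or nitrile, and whether it would persist with a longer chain linking the shared core to the six-membered ring. Each number is also a reading at a single concentration, so this pair shows a difference in inhibition at that concentration and does not give a potency for either compound.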